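The compounds below may be only part of what the source reports. "The series", "measured", "known", "first", "only" and "open" are said of these compounds alone.

Measured compounds and their results in an assay on CHO cells for antagonist activity at transient receptor potential cation channel subfamily V member 1 (Homo sapiens), read by FLIPR; on this read-out lower numbers stand for stronger inhibition and higher numbers for weaker inhibition:

Compound 1, `CC1CCN(c2nc(C(F)F)ccc2CNC(=O)C(C)c2ccc(NS(C)(=O)=O)c(F)c2)CC1`: compound 1 gives 1 nM.
Compound 2, `CC(C(=O)NCc1ccc(C2CC2)nc1N1CCCCC1)c1ccc(NS(C)(=O)=O)c(F)c1`: compound 2 gives 1.1 nM.
Compound 3, `CC1CC(C)CN(c2nc(C(F)(F)Cl)ccc2CNC(=O)C(C)c2ccc(NS(C)(=O)=O)c(F)c2)C1`: compound 3 gives 1 nM.

All three share the same amide-linked core and differ only in the saturated amine ring and in the small group across the pyridine. On these numbers compound 3 sits level with compound 1 at the digits shown, the two together at the lowest point of the three; compound 2 is its furthest neighbour, and even that gap lies within the scatter of this assay. In short, the three compounds are indistinguishable here.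

Compound 4, `CC(C(=O)NCc1ccc(C(F)(F)Cl)nc1N1CCN(c2ccccc2)CC1)c1ccc(NS(C)(=O)=O)c(F)c1`, has not yet been measured in this assay. It is made from compound 3 by a single change: 4-phenylpiperazin-1-yl in place of 3,5-dimethylpiperidin-1-yl on an aromatic carbon. The entering group is larger than the one it replaces and carries an extra aromatic ring. Among the measured compounds shown here, no measured pair covers a change of this size at this position, so no step can be read off. Because compound 3 gives 1 nM with room for variation in the amine ring among the three compounds, the expectation is that compound 4 stays potent, with a modest step of a 3.0-fold higher number from compound 3 to compound 4 (0.48 log units; beyond the scatter) toward a somewhat higher number that may not exceed the scatter. The estimate for compound 4 in this assay is 3 nM, with a likely range from 0.8 nM to 15 nM.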

Compound 4, inhibition constant: 0.8 nM
For compound 4 the middle estimate is 3.8-fold (0.57 log units) above the measured one; measured number inside the range.
By their numbers in this assay, from the lowest: compounds 4, 1, 3 and 2 (each within the scatter of the next).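

In this assay, putting 4-phenylpiperazin-1-yl in place of 3,5-dimethylpiperidin-1-yl gives a 1.3-fold lower number from compound 3 to compound 4 (0.10 log units; within the scatter), so the two compounds cannot be told apart. Among the compounds shown here, the earlier compounds carried only a single non-aromatic ring at this position, on an aromatic carbon next to the ring nitrogen, whereas this pair shows that a group of 12 heavy atoms with an added aromatic ring fits here as well as one of 8 heavy atoms, at least with the chloro(difluoro)methyl group in place. Nothing available explains why the larger group is accepted.

This single step changes the non-aromatic ring and adds the phenyl ring together, so the part played by each remains unseparated. Going by these compounds, it also remains open whether the position would accept a 4-benzylpiperazin-1-yl group or a phenyl ring bearing a carboxylic acid.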